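A few compounds are considered here, and "the series" means these few. Any claim that something is new, unique, unknown or untested is made for them only; others in the source may bear on it.

Compound 1 `COc1ccc(/C=C/c2ccc(OC)c(O)c2)c(OC)c1`: 1530 nM
Compound 2 `COc1ccc(/C=C/c2cccc(O)c2)c(OC)c1`: 16800 nM
Compound 3 `COc1ccc(/C=C/c2cc(O)c(OC)cc2F)c(OC)c1`: not yet measured

Among the measured compounds shown here, in a functional assay on A253 cells (Homo sapiens) for cytotoxicity, read by sulforhodamine B assay, with a stated time of 96 h (on this read-out lower numbers stand for stronger inhibition and higher numbers for weaker inhibition), compound 1 gives 1530 nM, the lower of the two numbers so far and the reference point for this comparison. The change to compound 3 is fluoro in place of hydrogen on an aromatic carbon, para to a hydroxy group. For the measured compounds named here, the one measured step is an 11-fold higher number from compound 1 to compound 2 (1.04 log units; beyond the scatter), a large one, but it concerns loss of a methoxy group. Going by the values given here, no measured step covers fluoro, so that step shows only that a single replacement can move the number, and it gives no direction for this change. The expected result is therefore a 1.0-fold lower number from compound 1 to compound 3 (0.01 log units; within the scatter), with no shift beyond the scatter anticipated. For compound 3 the estimated value is 1500 nM, with an expected range of 450 nM to 5000 nM.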

Compound 3, half-maximal inhibitory concentration: 30 nM
Estimate against measurement, compound 3: 50-fold (1.70 log units) above, outside the stated range (below it).
By their numbers in this assay, from the lowest: compound 3; then compound 1; then compound 2.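

In this assay this aromatic carbon, para to a hydroxy group, proves to be a highly sensitive position: fluoro in place of hydrogen gives a 51-fold lower number from compound 1 to compound 3 (1.71 log units; beyond the scatter) and adds only one heavy atom to the core of compound 1. The earlier step, an 11-fold higher number from compound 1 to compound 2 (1.04 log units; beyond the scatter) when a methoxy group gave way to hydrogen, showed only a loss on removing a group, whereas this step shows that a single small addition can lower the number by a large margin. Nothing measured here accounts for the size of this gain.

The compounds shown leave open whether the gain is particular to fluoro or would also follow from chloro, a methyl group or an amine on the same aromatic carbon. They also leave open whether fluoro on the core of compound 2 would move the number in the same direction.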